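This account rests on a few compounds, and the source may have more. Where it says the series, first, only, none or still open, it means among the compounds named here.

In an ADME assay on S9 fraction from liver (Mus musculus, strain CD-1) for metabolic stability, read by LC-MS, using NADPH, with stated times of 5 min and 60 min, tested at 5 uM (a lower number here means that less of the compound is left, a higher number that more of the compound is left), compound 3 `COc1cc(C2CN(C(=O)c3cc(COC[C@H](O)CO)ccn3)C2)ccc1OCc1ccc(C2CC2)cc1` gives 70%. Compound 1 `COc1cc(C2CN(C(=O)c3cc(OC[C@H](O)CO)ccn3)C2)ccc1OCc1ccc(C2CC2)cc1` gives 67% and compound 2 `COc1cc(C2CN(C(=O)c3cc(OCCCC(C)(C)C(=O)O)ccn3)C2)ccc1OCc1ccc(C2CC2)cc1` gives 76%, so the three values lie within the usual scatter of one another and compound 3 cannot be separated from either neighbour.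

Compound 4 `COc1cc(C2CN(C(=O)c3cc(COCC(CO)CO)ccn3)C2)ccc1OCc1ccc(C2CC2)cc1` differs from compound 3 only in the diol-bearing chain: 2-hydroxy-1-(hydroxymethyl)ethyl in place of 1,2-dihydroxyethyl on a saturated chain carbon bound to an oxygen on a saturated carbon. Read one bond further out, this is 2,3-dihydroxypropyl giving way to 3-hydroxy-2-(hydroxymethyl)propyl.

Among the measured compounds shown here, no measured pair makes this exact change, so the evidence is indirect. The closest step is a number 3 percentage points higher from compound 1 to compound 3 (within the scatter), a change of (2,3-dihydroxypropoxy)methyl for 2,3-dihydroxypropoxy on an aromatic carbon. The larger replacements give a number 9 percentage points higher from compound 1 to compound 2 (within the scatter) and a number 6 percentage points lower from compound 2 to compound 3 (within the scatter). Even the step to compound 2, which brings in a carboxy-bearing chain, stays inside the scatter in this assay, so the smaller rearrangement of the diol is expected to produce no step beyond the scatter, and no direction can be favoured.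

The estimated step is no change at the digits printed from compound 3 to compound 4 (within the scatter). The expected value for compound 4 is 70%, with an estimated range from 58% to 82%.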

Compound 4, percent of the compound remaining: 66%
The estimate for compound 4 lay 4 percentage points above the measured number; measured number inside the range.
By their numbers in this assay, from the lowest: compounds 4, 1, 3 and 2 (each within the scatter of the next).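

In this assay the chain carried on the saturated carbon can go from 2,3-dihydroxypropyl to 3-hydroxy-2-(hydroxymethyl)propyl, a group with no defined stereocentre, and the result is a number 4 percentage points lower from compound 3 to compound 4 (within the scatter) for this read-out. Seen against the other two compounds, the full replacement on the aromatic carbon gives a number 1 percentage points lower from compound 1 to compound 4 (within the scatter) when the starting group is 2,3-dihydroxypropoxy and a number 10 percentage points lower from compound 2 to compound 4 (within the scatter) when it is (4-carboxy-4-methylpentyl)oxy, so among these four compounds, each with the same shared core, no replacement at this place has yet given a step beyond the scatter. Nothing given here accounts for these numbers, and the assay read-out alone does not say where on the compounds the loss takes place.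

The compounds shown leave open whether an amine, a sulfonamide or a longer chain ending in a hydroxyl group at this place would also stay within the scatter in this assay and so whether the flat picture extends beyond diols and the one carboxylic acid. They also leave open whether the same tolerance would hold for a primary amide or a morpholine carried on the same chain.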